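Chlorine placement on the sulfanyl arm, compound 4

A few compounds are considered here, and "the series" means these few. Any claim that something is new, unique, unknown or untested is made for them only; others in the source may bear on it.

Compound 1 `CC1=C(C(=O)Nc2ccc([N+](=O)[O-])cc2)C(c2ccc(Br)cc2)N=C(SCc2ccccc2Cl)N1`, compound 2 `CC1=C(C(=O)Nc2ccc([N+](=O)[O-])cc2)C(c2ccc(Br)cc2)N=C(SCc2ccc(Cl)cc2)N1` and compound 3 `CC1=C(C(=O)Nc2ccc([N+](=O)[O-])cc2)C(c2cccc([N+](=O)[O-])c2)N=C(SCc2ccccc2Cl)N1` share one core. In a functional assay on the whole organism (artery, strain albino) with Rattus norvegicus as the target, with a stated time of 720 min, at a dose of 10 mg/kg by the oral route (a lower number here means less inhibition, a higher number more inhibition at the dose given (going by the name of the read-out)), compound 1 gives 6.7%, compound 2 gives 29.4% and compound 3 gives 11.3%. Compound 3 is thus second highest of the three numbers; its nearest neighbour is compound 1, within the scatter, while the gap to compound 2 is beyond the scatter. The step of a number 4.6 percentage points higher from compound 1 to compound 3 (within the scatter) lies within the scatter, so the change at the saturated ring carbon hardly moves the read-out. The step of a number 22.7 percentage points higher from compound 1 to compound 2 (beyond the scatter) is the one that bears on the present question.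

Compound 4 `CC1=C(C(=O)Nc2ccc([N+](=O)[O-])cc2)C(c2cccc([N+](=O)[O-])c2)N=C(SCc2ccc(Cl)cc2)N1` differs from compound 3 by 4-chlorophenyl in place of 2-chlorophenyl on a saturated chain carbon bound to a sulfur. The same change separates compound 1 from compound 2. An upward step of comparable size is therefore expected in this assay, namely a number 19.7 percentage points higher from compound 3 to compound 4 (beyond the scatter). The estimate for compound 4 in this assay is 31%, with a range from 14% to 48%; a single supporting step justifies only a wide range.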

Compound 4, a percentage reported as inhibition, in the whole organism at one dose (the size of the read-out at that dose, not a potency): 15.5%
Compound 4: the middle estimate sits 15.5 percentage points above what was measured, within the range that was stated.
By their numbers in this assay, from the lowest: compounds 1, 3 and 4 (each within the scatter of the next); then compound 2.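

In this assay, with 3-nitrophenyl on the saturated ring carbon, the move from 2-chlorophenyl to 4-chlorophenyl gives only a number 4.2 percentage points higher from compound 3 to compound 4 (within the scatter), so the gain seen with 4-bromophenyl does not carry over to this core: the same change on two cores in this assay, a number 22.7 percentage points higher (beyond the scatter) from compound 1 to compound 2 and a number 4.2 percentage points higher (within the scatter) from compound 3 to compound 4, 18.5 percentage points apart, beyond the scatter of two such steps. The change at the saturated ring carbon, with no readable effect when 2-chlorophenyl is present, does register when 4-chlorophenyl is present, as a number 13.9 percentage points lower from compound 2 to compound 4 (beyond the scatter): the same change on two cores in this assay, a number 4.6 percentage points higher (within the scatter) from compound 1 to compound 3 and a number 13.9 percentage points lower (beyond the scatter) from compound 2 to compound 4, 18.5 percentage points apart, beyond the scatter of two such steps. The two places therefore do not act independently in these compounds, and compound 2, which pairs 4-bromophenyl with 4-chlorophenyl, alone stands apart from the rest.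

As far as these compounds go, that pairing rests on a single compound at one dose and one time point, so its generality remains open. Also open, from the compounds shown here alone, is how an amine or a carboxylic acid in place of the chlorine would behave on either core.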